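The source may hold more compounds than are shown below. What is called first, only, known or untested is meant among the compounds shown, and "the series" means these compounds.

The three measured amides share one core and differ only in where the amide hangs on the fused bicyclic system. In a functional assay for antagonist activity at transient receptor potential cation channel subfamily V member 1 (Homo sapiens), read by FLIPR and calcium flux (on this read-out higher numbers stand for higher potency (the scale is a negative logarithm) and lower numbers for lower potency), compound 2 `CN1CCCc2cc(NC(=O)c3ccc(-c4ccccc4)cc3)ccc21` gives 7.1, while compound 3 `CN1CCCc2ccc(NC(=O)c3ccc(-c4ccccc4)cc3)cc21` gives 7.5. Compound 1 `CN1CCCc2c(NC(=O)c3ccc(-c4ccccc4)cc3)cccc21` reaches only a limit in this assay, < 6.5. For compound 1 that reading is the limit of < 6.5 in this assay, at which 1 of the 3 values shown sits. Among the two proper numbers, compound 3 stands highest, with compound 2 the nearest and lower by a margin that goes beyond the usual scatter of repeated measurements.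

Compound 4 `CC(=O)N1CCCc2ccc(NC(=O)c3ccc(-c4ccccc4)cc3)cc21` is the next member, and it has not yet been measured in this assay. It differs from compound 3 by acetyl in place of methyl on a nitrogen on an aromatic ring in a ring. Going by the values given here, no pair among the measured compounds shows a change of this kind, so the direction of the step cannot be read from the numbers in hand. A modest downward step, of roughly the size of the scatter and no larger, is the expectation here, since the amide and the biphenyl that carry the activity in compounds 2 and 3 are untouched. The expected step is a number 0.30 log units lower from compound 3 to compound 4 (within the scatter). Compound 4 is therefore estimated at 7.2, with a range from 6.3 to 7.9.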

Compound 4, negative logarithm of the antagonist equilibrium constant: 7.2
For compound 4 middle estimate and measured number coincide at the digits printed; the range from low to high includes it.
By their numbers in this assay, from the lowest: compounds 2, 4 and 3 (each within the scatter of the next, the first and the last beyond it). At a limit, below all of these: compound 1.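

In this assay, acetyl in place of methyl on a nitrogen on an aromatic ring in a ring gives a number 0.30 log units lower from compound 3 to compound 4 (within the scatter), the first step shown at this nitrogen, since compounds 1, 2 and 3 differ only in where the amide hangs on the shared core. The change replaces one carbon with a group of more heavy atoms that brings a double bond outside aromatic rings and a hydrogen-bond acceptor, and the read-out stays within the scatter, so this position accepts acetyl as well as methyl in this one pair. Nothing shown bears on why the two values lie so close together.

This single pair cannot say how far that latitude extends: a hydrogen on the nitrogen, a longer chain such as propyl, a sulfonyl group or a chain ending in an amine or a carboxylic acid could each behave differently. From the compounds shown here alone, it also remains open whether acetyl in place of methyl gives a similar step when the amide sits where it does in compound 2 or compound 1.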